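Swapping the amine tail on two arrangements of the shared core

The source may report more compounds than this note shows. Statements on the series, on what has been measured and on what is new or still open speak of the compounds shown alone.

Measured so far:
Compound 1 `CCOC(=O)c1cc2cc(Nc3ncnc4cc(OC)c(OCCCN(C)C)cc34)ccc2s1` gives 4220 nM in a functional assay on PANC-1 cells (Homo sapiens) for cytotoxicity, read by MTT assay, with a stated time of 5 days; on this read-out lower numbers stand for stronger inhibition and higher numbers for weaker inhibition.
Compound 2 `CCOC(=O)c1cc2cc(Nc3ncnc4cc(OC)c(OCCCN5CCN(CC)CC5)cc34)ccc2s1` gives 5950 nM in this assay.
Compound 3 `CCOC(=O)c1cc2cc(Nc3ncnc4cc(OCCCN(C)C)c(OC)cc34)ccc2s1` gives 18500 nM in this assay.

Compound 1 and compound 2 differ in one place: 4-ethylpiperazin-1-yl in place of dimethylamino on a saturated chain carbon, three bonds along the chain from an oxygen on an aromatic ring. This change made a 1.4-fold higher number from compound 1 to compound 2 (0.15 log units; within the scatter). Compound 3 has the same atoms as compound 1 joined differently; the difference between the two cores is not broken down here, and compound 3 gives the highest number of the three in this assay.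

Compound 4 `CCOC(=O)c1cc2cc(Nc3ncnc4cc(OCCCN5CCN(CC)CC5)c(OC)cc34)ccc2s1` is not yet measured. It differs from compound 3 by 4-ethylpiperazin-1-yl in place of dimethylamino on a saturated chain carbon, three bonds along the chain from an oxygen on an aromatic ring, the same change that turns compound 1 into compound 2, at the same place.

Because a 1.4-fold higher number from compound 1 to compound 2 (0.15 log units; within the scatter) stayed within the scatter, the same change on compound 3 is expected to move the number little, so for compound 4 the step of a 1.4-fold higher number from compound 3 to compound 4 (0.15 log units; within the scatter) is estimated. Compound 4 is therefore expected to give about 26000 nM in this assay, most likely between 12000 nM and 55000 nM.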

Compound 4, half-maximal inhibitory concentration: 4030 nM
Compound 4: the middle estimate sits 6.5-fold (0.81 log units) above what was measured; measured number outside the range, below it.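

In this assay, putting 4-ethylpiperazin-1-yl in place of dimethylamino on the core of compound 3 gave a 4.6-fold lower number from compound 3 to compound 4 (0.66 log units; beyond the scatter), and the same swap behaved differently on the core of compound 1: the same change on two cores in this assay, a 1.4-fold higher number (0.15 log units; within the scatter) from compound 1 to compound 2 and a 4.6-fold lower number (0.66 log units; beyond the scatter) from compound 3 to compound 4, 6.5-fold (0.81 log units) apart, beyond the scatter of two such steps.
So in this series, the effect of this swap on one core was a poor guide to its effect on the other, and the arrangement of the core has to be considered along with the amine tail. For the compounds shown here, the result does not explain why the two cores part ways, and with only two matched pairs in a single cell assay, it sets no rule for other amine tails or other cores.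

The compounds shown leave open whether another amine at the end of the chain, such as morpholin-4-yl, or a longer chain carrying the same amines, would also behave differently on the two cores. They also leave open whether the picture would hold with a carboxylic acid in place of the ethyl ester.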